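The source may hold more compounds than are shown below. What is called first, only, known or untested is meant among the compounds shown, and "the series" means these compounds.

Working notes on the series.

For the measured compounds named here, compound 1 `O=C(c1cccc(OC(F)(F)F)c1)N1CCC(N(C2CC2)S(=O)(=O)c2cccc(C(F)(F)F)c2)CC1` is the only member with a number: in an assay on cells for inhibition of Voltage-dependent L-type calcium channel subunit alpha-1C (Homo sapiens), read by FLIPR and calcium flux, tested at 3 uM (on this read-out lower numbers stand for a weaker effect and higher numbers for a stronger effect at the one concentration tested), compound 1 gives 78%. Compound 2 `NC(=O)c1cccc(C(=O)N2CCC(N(C3CC3)S(=O)(=O)c3cccc(C(F)(F)F)c3)CC2)c1` belongs to the same core, but in this assay compound 2 gives "not determined" (no result reported), so compound 1 stands alone as the single reference point, with nothing measured to compare it against.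

Compound 3 `CS(=O)(=O)c1ccc(F)cc1C(=O)N1CCC(N(C2CC2)S(=O)(=O)c2cccc(C(F)(F)F)c2)CC1` has not yet been run in this assay. It differs from compound 1 in one place: 5-fluoro-2-(methylsulfonyl)phenyl in place of 3-(trifluoromethoxy)phenyl on a carbonyl carbon. Going by the values given here, no step between two measured compounds is available, so the direction and size of the effect must be taken from the change itself, worded as an expectation.

The step from compound 1 to compound 3 in this assay is expected to be downward and beyond the usual scatter, at about a number 33 percentage points lower from compound 1 to compound 3 (beyond the scatter). Compound 3 is estimated at 45% in this assay, with a range from 15% to 75%.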

Compound 3, a percentage reported as inhibition, at one concentration (the size of the read-out at that concentration, not a potency): 34%
Beside the measured number, compound 3's estimate is 11 percentage points above it; the measured number falls inside the stated range.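

The group on a carbonyl carbon now proves to be a sensitive place in this assay: 5-fluoro-2-(methylsulfonyl)phenyl in place of 3-(trifluoromethoxy)phenyl gives a number 44 percentage points lower from compound 1 to compound 3 (beyond the scatter). The step arises with no change in heavy-atom count, as both groups have 11 heavy atoms and one six-membered aromatic ring of carbon only, while the entering group brings sulfur, 2 double bonds outside aromatic rings and 2 hydrogen-bond acceptors against 1. Nothing available explains the drop.

The compounds shown change these features together, so the step cannot be assigned to the methylsulfonyl, the fluorine or the departure of the trifluoromethoxy. Going by these compounds, how a plain phenyl, or a phenyl bearing only a methylsulfonyl or an amine, would behave at this place remains open.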